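This account rests on a few compounds, and the source may have more. Where it says the series, first, only, none or still open, it means among the compounds named here.

Measured so far in an ADME assay on Vero cells (Chlorocebus sabaeus) for cytotoxicity, read by resazurin assay, with a stated time of 24 h; on this read-out higher numbers stand for lower toxicity in this test and lower numbers for higher toxicity in this test
compound 1 (`CCCCCCO[C@@H]1C=CC(=O)[C@@H](COC(=O)C(C)(C)C)O1`): 4800 nM
compound 2 (`CC(C)CCO[C@@H]1C=CC(=O)[C@@H](COC(=O)C(C)(C)C)O1`): 36000 nM
compound 3 (`CC(C)CO[C@@H]1C=CC(=O)[C@@H](COC(=O)C(C)(C)C)O1`): 28200 nM

Compound 3 sits with the upper pair of numbers, and that pair shows no real separation (a 1.3-fold lower number from compound 2 to compound 3 (0.11 log units; within the scatter)). Compound 1 has the lowest number, clearly apart from compound 3 (a 5.9-fold higher number from compound 1 to compound 3 (0.77 log units; beyond the scatter)) and from compound 2 (a 7.5-fold higher number from compound 1 to compound 2 (0.88 log units; beyond the scatter)).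

The next compound is compound 4 (`CC(C)(C)C(=O)OC[C@H]1O[C@H](OCC2CC2)C=CC1=O`), not yet measured. The change is cyclopropyl in place of isopropyl on a saturated chain carbon bound to an oxygen on a saturated carbon. Read one bond further out, it is isobutoxy to cyclopropylmethoxy.

For the measured compounds named here, no measured step makes this exact swap. The closest is the step at the same place, isopropyl in place of isobutyl, which stayed within the scatter (a 1.3-fold lower number from compound 2 to compound 3 (0.11 log units; within the scatter)). The two modest steps both start from compound 1, so they describe leaving its chain and say little about a swap among groups of this size. On that basis, no step beyond the scatter is expected in this assay, and no direction can be argued from these data. The estimated step is small (a 1.1-fold lower number from compound 3 to compound 4 (0.05 log units; within the scatter)). For compound 4 the expected value is 25000 nM, with an estimated range of 12000 nM to 50000 nM.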

Compound 4, half-maximal cytotoxic concentration: 77200 nM
For compound 4 the middle estimate is 3.1-fold (0.49 log units) below the measured one, and the stated range ends below it.
By their numbers in this assay, from the lowest: compound 1; then compounds 3 and 2 (each within the scatter of the next); then compound 4.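

In this assay, cyclopropyl in place of isopropyl on a saturated chain carbon bound to an oxygen on a saturated carbon gives a step beyond the scatter (a 2.7-fold higher number from compound 3 to compound 4 (0.44 log units; beyond the scatter)), so an exchange between groups of equal heavy-atom count can register at this place, which the isopropyl for isobutyl step (a 1.3-fold lower number from compound 2 to compound 3 (0.11 log units; within the scatter)) gave no sign of. Compound 4 also stands clear of compound 2 (a 2.1-fold higher number from compound 2 to compound 4 (0.33 log units; beyond the scatter)) and furthest from compound 1 (a 16-fold higher number from compound 1 to compound 4 (1.21 log units; beyond the scatter)), which gives it the highest number of the four and thus the lowest toxicity in this test, and it shows that the upper pair did not mark a ceiling for this series. No measured finding on hand accounts for this step.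

The compounds shown do not separate the effect of a ring as such from that of a three-membered ring, a question that cyclobutylmethoxy or cyclopentylmethoxy at this place could address. Going by these compounds, how an amine or a carboxylic acid on this chain would read in this assay also remains open.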